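The compounds below may be only part of what the source reports. "The series", "measured", "known", "first", "only" and "open" are said of these compounds alone.

Measured in a functional assay (BAEC cells, Bos taurus) for inhibition, read by cell counting, with a stated time of 3 days; a lower number here means a stronger inhibitor, a higher number a weaker inhibitor:
- Compound 1 `COc1ccc(N(C)c2nc(C)nc3c2nc(C)n3C)cc1`: 7400 nM
- Compound 2 `COc1ccc(Nc2nc(C)nc3c2nc(C)n3C)cc1`: >= 100000 nM (a limit)

Compound 2 has no numerical value on this read-out, the half-maximal inhibitory concentration. Its >= 100000 nM is a limit of the assay and not a number. The evidence therefore places it at the limit of >= 100000 nM in this assay, at which 1 of the 2 values shown sits.

The next compound to be tested is compound 3 `CCN(c1ccc(OC)cc1)c1nc(C)nc2c1nc(C)n2C`. It carries ethyl in place of hydrogen on a nitrogen on an aromatic ring.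

Among the measured compounds shown here, only one measured step bears on this change. That step is an at least 13-fold higher number from compound 1 to compound 2 (1.13 log units; beyond the scatter), where hydrogen takes the place of methyl on a nitrogen on an aromatic ring. It is large and lies beyond the scatter. Ethyl itself has not been measured at this nitrogen, so the reading is indirect. Taken in reverse, the step suggests a large move to a lower number in this assay once the hydrogen is replaced.

The expected step is an at least 10-fold lower number from compound 2 to compound 3 (1.00 log units; beyond the scatter). For compound 3 the estimated value is 10000 nM, with an expected range from 3000 nM to 40000 nM.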

Compound 3, half-maximal inhibitory concentration: 11000 nM
Estimate against measurement, compound 3: 1.1-fold (0.04 log units) below, within the range that was stated.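

In this assay, among the compounds shown here, the earlier compounds showed the effect of only one group on this nitrogen on an aromatic ring, and the new result shows that the effect is not confined to methyl: ethyl in place of hydrogen gives an at least 9.0-fold lower number from compound 2 to compound 3 (0.95 log units; beyond the scatter). Ethyl and methyl at this nitrogen cannot be told apart on this read-out, since the comparison gives a 1.5-fold higher number from compound 1 to compound 3 (0.17 log units; within the scatter), so what the three compounds separate is a hydrogen on this nitrogen from a small saturated chain, and not one chain from the other. Compound 2 is a limit and not a number, so both steps that start or end at it fix the size of the difference from one side only: the limit of >= 100000 nM in this assay, at which 1 of the 3 values shown sits.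

The compounds shown leave open how far this tolerance of a chain on the nitrogen extends, for instance to a longer chain such as propyl or butyl, to a branched isopropyl, or to a chain ending in an amine or a hydroxyl. They also leave open whether the same pattern holds when the methoxy group or the shared core is changed.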